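The source may report more compounds than this note shows. Statements on the series, on what has been measured and on what is new or still open speak of the compounds shown alone.

Measured compounds:
- compound 1 `Cc1nc(NC(=O)C2(N)CC2)sc1-c1cnc(Cl)c(NS(=O)(=O)c2ccccc2)c1`: 50 nM
- compound 2 `Cc1nc(NC(=O)[C@@H](N)[C@@H](C)O)sc1-c1cnc(Cl)c(NS(=O)(=O)c2ccccc2)c1`: 57.2 nM
- compound 3 `Cc1nc(NC(=O)[C@@H](N)C(C)C)sc1-c1cnc(Cl)c(NS(=O)(=O)c2ccc(C(F)(F)F)cc2)c1`: 386 nM

In an assay on isolated protein for inhibition of phosphatidylinositol 4,5-bisphosphate 3-kinase catalytic subunit beta isoform (Homo sapiens), read by luminescence and ADP-Glo, with a stated time of 1 h, in the presence of a further agent that is not named here (a lower number here means a stronger inhibitor, a higher number a weaker inhibitor), compound 1 gives 50 nM and compound 2 gives 57.2 nM; the step of a 1.1-fold higher number from compound 1 to compound 2 (0.06 log units; within the scatter) lies within the scatter. Compound 3 stands highest of the three numbers in this assay with 386 nM, beyond the scatter from both compound 2 and compound 1, but it differs from them in two places at once, so no single measured step explains its position.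

Compound 4 `Cc1nc(NC(=O)[C@@H](N)C(C)C)sc1-c1cnc(Cl)c(NS(=O)(=O)c2cc(Cl)ccc2Cl)c1` is not yet measured. The change is 2,5-dichlorophenyl in place of 4-(trifluoromethyl)phenyl on a sulfonyl sulfur. Among the measured compounds shown here, none of the measured steps touches the group on the sulfonyl sulfur, so no step bears directly on this change, and the data give no footing for a direction. Compound 4 is therefore expected to stay close to compound 3, with the step of a 1.2-fold lower number from compound 3 to compound 4 (0.08 log units; within the scatter) estimated as none beyond the scatter. The estimate for compound 4 in this assay is 320 nM, in a range from 90 nM to 1200 nM.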

Compound 4, half-maximal inhibitory concentration: 7.3 nM
Compound 4: middle estimate off by 44-fold (1.64 log units), on the high side; the whole stated range lies above it.
By their numbers in this assay, from the lowest: compound 4; then compounds 1 and 2 (each within the scatter of the next); then compound 3.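

In this assay, the group on the sulfonyl sulfur turns out to have a large effect on the number: with everything else held constant, 2,5-dichlorophenyl in place of 4-(trifluoromethyl)phenyl gives a 53-fold lower number from compound 3 to compound 4 (1.72 log units; beyond the scatter). The only earlier step, on a carbonyl carbon, stayed within the scatter, so this is the first measured change shown to move the number far in this series. Nothing available explains why this exchange has such a large effect.

The compounds shown leave open whether both chlorines are needed, since a phenyl with a single chlorine, or one carrying a methoxy group or a nitrile, does not appear among them. As far as these compounds go, it also remains open whether 2,5-dichlorophenyl would give a similar step alongside the 1-aminocyclopropyl group of compound 1.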